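A few compounds are considered here, and "the series" means these few. Any claim that something is new, unique, unknown or untested is made for them only; others in the source may bear on it.

Working notes on a series built on a shared core, examined for cytotoxicity in an ADME assay on BJ cells (Homo sapiens) for cytotoxicity, with a stated time of 72 h; on this read-out lower numbers stand for an effect already at smaller amounts and higher numbers for an effect only at larger amounts of compound. Compound 1 `CCc1ccc(NC(=O)Nc2cc(C)nc3ccccc23)cc1` returns in this assay only a limit, > 25000 nM. Compound 2 `CSc1ccccc1NC(=O)Nc1cc(C)nc2ccccc12` likewise gives in this assay only a limit, > 25000 nM. Compound 3 `COC(=O)c1cccc(NC(=O)Nc2cc(C)nc3ccccc23)c1` reaches a number in this assay, 21000 nM. Compound 1 thus stands at the limit of > 25000 nM in this assay, at which 2 of the 3 values shown sit, without a number of its own. Compound 4 `Cc1cc(NC(=O)Nc2ccc(OC(F)(F)F)cc2)c2ccccc2n1` is not yet measured and differs from compound 1 in one place: trifluoromethoxy in place of ethyl on an aromatic carbon. Going by the values given here, no two measured compounds differ in a single place, so no step size is known from the data. For this assay the change is expected to bring no shift beyond the scatter, a step that the limit leaves unreadable from compound 1 to compound 4. Compound 4 is expected to give 30000 nM, between 15000 nM and 60000 nM, most likely again only a limit.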

Compound 4, half-maximal effective concentration: 25000 nM
For compound 4 the middle estimate is 1.2-fold (0.08 log units) above the measured one, and the stated range covers the measured number.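

In this assay, trifluoromethoxy in place of ethyl, on an aromatic carbon para to a large group, gives a number no higher from compound 1 to compound 4 (the limit leaves the size open). Going by these compounds alone, this is the first change at a single place, and it yields a number where the ethyl compound gave none. Its size stays unreadable because one end of the step is a limit: the limit of > 25000 nM in this assay, at which 2 of the 4 values shown sit.

The compounds shown leave open how an amine, a carboxylic acid or a longer chain would read at this place. Also open, from the compounds shown here alone, is whether any group there brings a value clearly lower.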